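The compounds below may be only part of what the source reports. "The series", "measured", "known", "first", "only" and "open" are said of these compounds alone.

Compounds measured in an assay on isolated protein with Bile acid receptor (Homo sapiens) as the target; on this read-out lower numbers stand for an effect already at smaller amounts and higher numbers for an effect only at larger amounts of compound: compound 1 `COC(=O)/C=C/c1cccc(N(Cc2ccc(/C=C/C(=O)N(C)C)cc2)C(=O)C2CCCCC2)c1`, compound 2 `COC(=O)/C=C/c1cccc(N(Cc2ccc(/C=C/C(=O)O)cc2)C(=O)C2CCCCC2)c1`, compound 3 `COC(=O)/C=C/c1cccc(N(Cc2ccc(/C=C/c3c(Cl)cccc3Cl)cc2)C(=O)C2CCCCC2)c1`.

In this assay compound 1 stops at a limit, > 1000 nM. Compound 2 likewise reaches only a limit, > 1000 nM. Within the data shown here, compound 3 is the one member of the set with a number, 150 nM, so it stands as the only read value among the three. Compound 4 `COC(=O)/C=C/c1cccc(N(Cc2ccc(-c3ccc(OC(F)(F)F)cc3)cc2)C(=O)C2CCCCC2)c1` differs from it by 4-(trifluoromethoxy)phenyl in place of 2-(2,6-dichlorophenyl)ethenyl on an aromatic carbon. Among the measured compounds shown here, two measured steps bear on this change: an at least 6.6-fold lower number from compound 1 to compound 3 (0.82 log units; beyond the scatter) and an at least 6.6-fold lower number from compound 2 to compound 3 (0.82 log units; beyond the scatter), both replacing a polar terminus by an aromatic ring. Compound 4 keeps an aromatic ring at this position, so compound 4 is expected to show a 2.0-fold higher number from compound 3 to compound 4 (0.30 log units; within the scatter), at most a modest shift, and its value is estimated at 300 nM, within 80 nM to 1200 nM.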

Compound 4, half-maximal effective concentration: 264 nM
Beside the measured number, compound 4's estimate is 1.1-fold (0.06 log units) above it; the range from low to high includes it.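

In this assay, 4-(trifluoromethoxy)phenyl in place of 2-(2,6-dichlorophenyl)ethenyl gives a 1.8-fold higher number from compound 3 to compound 4 (0.25 log units; within the scatter), so neither the double bond outside the aromatic rings nor the chlorines are required at this place. A second aromatic group also separates from the acid and amide ends, with an at least 3.7-fold lower number from compound 2 to compound 4 (0.57 log units; beyond the scatter) and an at least 3.7-fold lower number from compound 1 to compound 4 (0.57 log units; beyond the scatter). Both of these steps rest on a limit: the limit of > 1000 nM in this assay, at which 2 of the 4 values shown sit.

The compounds shown leave open whether an amine or a longer chain at this aromatic carbon would give similar values. They also leave open how a carboxylic acid in place of the methyl ester would read.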